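Aryl group swap on the piperazine in the oxazole series

The compounds below may be only part of what the source reports. "The series", "measured", "known", "first", "only" and "open" are said of these compounds alone.

Of the compounds shown here, three have been measured in an assay on HEK293 cells for inhibition of Voltage-dependent T-type calcium channel subunit alpha-1G (Homo sapiens), read by fluorescence, tested at 10 uM; a higher number here means more inhibition at the concentration tested (going by the name of the read-out), a lower number less inhibition. Compound 1 `CCCc1nc(-c2ccccc2)c(CNCCCN2CCN(c3ccc(OC)cc3)CC2)o1` gives 42.1% in this assay. Compound 2 `CCCc1nc(-c2ccccc2)c(CNCCN2CCN(c3ccccc3C(F)(F)F)CC2)o1` gives 54.6% in this assay. Compound 3 `CCCc1nc(-c2ccccc2)c(CNCCCN2CCN(c3ccccc3C(F)(F)F)CC2)o1` gives 45% in this assay. The number for compound 2 is beyond the scatter from that of compound 1, but within the scatter of that of compound 3, so compound 2 and compound 3 are not separated by this assay. The difference between the core of compound 2 and the core of compound 3 is not broken down here.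

One structural change occurs twice among the compounds shown. From compound 3 to compound 1 it is 4-methoxyphenyl in place of 2-(trifluoromethyl)phenyl on an amine nitrogen in a ring, and it made a number 2.9 percentage points lower from compound 3 to compound 1 (within the scatter). From compound 2 to compound 4 it is 4-methoxyphenyl in place of 2-(trifluoromethyl)phenyl on an amine nitrogen in a ring, the same change, since the place is the same in both cases. Compound 4 `CCCc1nc(-c2ccccc2)c(CNCCN2CCN(c3ccc(OC)cc3)CC2)o1` has not yet been measured in this assay.

The expectation for compound 4 is a step of a number 2.6 percentage points lower from compound 2 to compound 4 (within the scatter) in this assay, because the same change made a number 2.9 percentage points lower from compound 3 to compound 1 (within the scatter). This rests on a single measured pair, so the expected step is taken as close to nothing, with the usual scatter around it. The estimate for compound 4 in this assay is 52%, expected to fall between 38% and 64%.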

Compound 4, a percentage reported as inhibition, at one concentration (the size of the read-out at that concentration, not a potency): 51.5%
The estimate for compound 4 lay 0.5 percentage points above the measured number; the measured number falls inside the stated range.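

Across the aryl swap, 4-methoxyphenyl in place of 2-(trifluoromethyl)phenyl on an amine nitrogen in a ring, this assay now gives a second step, a number 3.1 percentage points lower from compound 2 to compound 4 (within the scatter). The swap behaves alike on the core of compound 2 and the core of compound 3, with no difference between the two steps that this read-out can separate: the same change on two cores in this assay, a number 2.9 percentage points lower (within the scatter) from compound 3 to compound 1 and a number 3.1 percentage points lower (within the scatter) from compound 2 to compound 4, 0.2 percentage points apart, within the scatter of two such steps. Going by these compounds alone, this shows only that a swap with no step beyond the scatter stays that way on these two cores; with both steps inside the scatter, it does not show that a step of real size would carry from one core to the other, and two pairs at a single tested concentration say nothing about potency or about any further core.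

Still open, going by these compounds, is whether the same agreement between the two cores holds for other groups on that ring nitrogen, such as a benzyl or an acetyl group, where a step beyond the scatter might appear. Also open, on these data alone, is how the series responds to changes elsewhere, such as a cyclopropyl group in place of the propyl chain or an amide in place of the open-chain amine.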